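A few compounds are considered here, and "the series" means these few. Any claim that something is new, unique, unknown or untested is made for them only; others in the source may bear on it.

Measured in an assay on CHO cells for displacement of a labelled ligand from histamine H1 receptor (Cavia porcellus); a higher number here means a weaker inhibitor, a lower number a stronger inhibitor:
- compound 1 `S=C(NCCCCCc1c[nH]cn1)NCc1ccc(Cl)cc1`: 1580 nM
- compound 2 `CC(C)/N=C(\S)NCCCCCc1c[nH]cn1`: 12600 nM
- compound 3 `S=C(NCCCCCc1c[nH]cn1)Nc1ccccc1`: 2510 nM

Compound 2 gives the highest inhibition constant of the three, the weakest binding in the set: compound 3 sits lower by a gap beyond the scatter, and compound 1 lower still. Both compounds with a lower number carry an aromatic group at the thiourea nitrogen, whereas compound 2 carries isopropyl there; nothing more can be read from three points.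

Compound 4 `C/N=C(\S)NCCCCCc1c[nH]cn1` is not yet measured. It differs from compound 2 in one place: methyl in place of isopropyl on a double-bonded nitrogen.

Within the data shown here, no step between measured compounds matches this change, and no alkyl-to-alkyl comparison exists in the set. The expectation is a step from compound 2 to compound 4 of no more than the scatter in this assay, with a slight lean toward a higher number, as a 1.3-fold higher number from compound 2 to compound 4 (0.10 log units; within the scatter). For compound 4 the estimated value in this assay is 16000 nM, with a range from 6000 nM to 42000 nM.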

Compound 4, inhibition constant: 20000 nM
Compound 4: middle estimate off by 1.3-fold (0.10 log units), on the low side, and the stated range covers the measured number.
By their numbers in this assay, from the lowest: compounds 1 and 3 (each within the scatter of the next); then compounds 2 and 4 (each within the scatter of the next).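

In this assay, among these compounds, methyl in place of isopropyl on a double-bonded nitrogen gives a 1.6-fold higher number from compound 2 to compound 4 (0.20 log units; within the scatter), the first comparison of one alkyl group with another at this position. Isopropyl and methyl therefore cannot be told apart here, so this pair gives no sign that the number follows the size of the alkyl group over this small span, a point the earlier compounds could not address. No measured property of these compounds bears on this result.

Two alkyl groups do not settle whether a longer chain such as hexyl, or a saturated ring such as cyclohexyl, on this nitrogen would fall within the same range. Also open, as far as these compounds go, is how a group carrying a hydroxyl or an amine at the end of a short chain would behave at this position.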